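Changing the group on the ring nitrogen of a piperidine ether

The source may hold more compounds than are shown below. What is called first, only, known or untested is meant among the compounds shown, and "the series" means these compounds.

Three compounds that share one core differ only in the group attached to an amine nitrogen in a ring. Compound 1 `CCOC(=O)N1CCC(Oc2ncnc3c2CCN3c2ccc(S(C)(=O)=O)cc2F)CC1` carries an ethoxycarbonyl group; in a functional assay on CHO-K1 cells for agonist activity at Glucose-dependent insulinotropic receptor (Homo sapiens), read by a luciferase reporter, with a stated time of 5 h (on this read-out higher numbers stand for an effect only at larger amounts of compound and lower numbers for an effect already at smaller amounts), compound 1 gives 251 nM. Compound 2 `CCCCOC(=O)N1CCC(Oc2ncnc3c2CCN3c2ccc(S(C)(=O)=O)cc2F)CC1` has a longer chain, and in this assay compound 2 gives 50.1 nM, which is a 5.0-fold lower number from compound 1 to compound 2 (0.70 log units; beyond the scatter). Compound 3 `CC(C)(C)COC(=O)N1CCC(Oc2ncnc3c2CCN3c2ccc(S(C)(=O)=O)cc2F)CC1` carries a neopentyloxycarbonyl group, and in this assay compound 3 gives 39.8 nM. Against compound 1 this is a 6.3-fold lower number from compound 1 to compound 3 (0.80 log units; beyond the scatter), while against compound 2 it is only a 1.3-fold lower number from compound 2 to compound 3 (0.10 log units; within the scatter). Compound 3 thus has the lowest number of the three, though it cannot be told apart from compound 2.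

Compound 4 `CS(=O)(=O)c1ccc(N2CCc3c(OC4CCN(C(=S)Sc5ccccc5)CC4)ncnc32)c(F)c1` introduces a different kind of change: a group of 9 heavy atoms (7 carbon, 2 sulfur; one six-membered aromatic ring of carbon only) in place of a group of 8 heavy atoms (6 carbon, 2 oxygen; no ring), on an amine nitrogen in a ring. The two measured steps that lowered the number both enlarged a saturated chain, so they bear only loosely on a group that brings a ring and two sulfur atoms. Among the measured compounds shown here, with no closer precedent, compound 4 is expected to stay near compound 3, with a 1.6-fold higher number from compound 3 to compound 4 (0.20 log units; within the scatter) as the likely step. For compound 4 the estimate in this assay is 63 nM, with a range from 16 nM to 250 nM.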

Compound 4, half-maximal effective concentration: 12.6 nM
Beside the measured number, compound 4's estimate is 5.0-fold (0.70 log units) above it; measured number outside the range, below it.
By their numbers in this assay, from the lowest: compound 4; then compounds 3 and 2 (each within the scatter of the next); then compound 1.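

In this assay, a group bearing an aromatic ring and two sulfur atoms on the amine nitrogen gives a lower number than either longer chain, with a 3.2-fold lower number from compound 3 to compound 4 (0.50 log units; beyond the scatter) and a 4.0-fold lower number from compound 2 to compound 4 (0.60 log units; beyond the scatter). Against the ethoxycarbonyl group the gap is wider, with a 20-fold lower number from compound 1 to compound 4 (1.30 log units; beyond the scatter), so a low number at this position does not depend on a saturated chain or on the oxygen atoms of the earlier groups. Nothing available explains why this group gives the lower number.

The ring and the sulfur atoms enter together, and the compounds shown cannot separate their shares. Going by these compounds, it remains open how a phenoxycarbonyl group, with oxygen in place of both sulfur atoms, or a pyridine ring in place of the carbon-only ring would behave here.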